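Iodo to ethyl on two cores: expected cytotoxicity

The source may report more compounds than this note shows. Statements on the series, on what has been measured and on what is new or still open speak of the compounds shown alone.

Compound 1 `C=C1C(n2cc(I)c(=O)[nH]c2=O)O[C@H](CO)[C@@H]1O` and compound 2 `C=C1C(n2cc(CC)c(=O)[nH]c2=O)O[C@H](CO)[C@@H]1O` share one core and differ only in that compound 2 carries ethyl in place of iodo on an aromatic carbon. Compound 3 `C=C1C(n2cc(I)c(N)nc2=O)O[C@H](CO)[C@@H]1O` is built on another core; how its core differs from the core of compound 1 is not broken down here. Compound 4 `C=C1C(n2cc(CC)c(N)nc2=O)O[C@H](CO)[C@@H]1O` is the unmeasured partner of compound 3 and carries ethyl in place of iodo on an aromatic carbon. The two exchanges are the same kind of change, though the surroundings are described differently: in compound 1 the site is ortho to a group of 1 heavy atom, whereas in compound 3 it is ortho to an amino group (1 heavy atom).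

In a functional assay on L1210 cells (Mus musculus) for cytotoxicity (on this read-out higher numbers stand for weaker inhibition and lower numbers for stronger inhibition), compound 1 gives only a limit, > 100 ug/mL. In this assay compound 2 likewise gives only a limit, > 100 ug/mL. For compound 3 this assay again reports only a limit, > 100 ug/mL. The step that the two limits leave unreadable from compound 1 to compound 2 therefore cannot be read in size. What all three share is the limit of > 100 ug/mL in this assay, at which 3 of the 3 values shown sit.

The step that the two limits leave unreadable from compound 1 to compound 2 shows the same kind of change leaving both of its compounds at the limit. On that ground compound 4 is expected to give around 150 ug/mL, within a range from 50 ug/mL to 500 ug/mL. The expected step is a step that the limit leaves unreadable from compound 3 to compound 4, which means essentially no change, most likely reported again as a limit rather than a number.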

Compound 4, half-maximal inhibitory concentration: > 100 ug/mL
Compound 4: no number, only a limit; the forecaster's own chance of this, stated with the estimate: 85%; the middle value does not contradict the limit.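

In this assay compound 4 gives > 100 ug/mL as a limit and not a number. Among the compounds shown here, compound 3 also gives only a limit, so the exchange of iodo for ethyl between compound 3 and compound 4 yields no step that can be read. The four compounds share one result: the limit of > 100 ug/mL in this assay, at which 4 of the 4 values shown sit. They leave open how strongly, if at all, any of them inhibits these cells, and whether this exchange changes that on either core.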